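Carrying a Methyl-for-Iodo Swap onto a Second Core

This account rests on a few compounds, and the source may have more. Where it says the series, first, only, none or still open, it means among the compounds named here.

Compound 1 `Ic1ccc(NC2=NCCO2)cc1` and compound 2 `Cc1ccc(NC2=NCCO2)cc1` share one core, while compound 3 `O=C(CCl)NC(=O)Nc1ccc(I)cc1` is built on another; the difference between the two cores is not broken down here. In a functional assay on M21 cells (Homo sapiens) for inhibition, read by sulforhodamine B assay, with a stated time of 48 h (on this read-out higher numbers stand for weaker inhibition of growth and lower numbers for stronger inhibition of growth), compound 1 gives 2000 nM and compound 2 gives 22000 nM. The step of an 11-fold higher number from compound 1 to compound 2 (1.04 log units; beyond the scatter) rests on a single alteration, (methyl in place of iodo on an aromatic carbon). In this assay compound 3 gives 4200 nM, a number between those of compound 1 and compound 2.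

Compound 4 `Cc1ccc(NC(=O)NC(=O)CCl)cc1` has not yet been measured. It differs from compound 3 by methyl in place of iodo on an aromatic carbon. This is the same kind of change as that between compound 1 and compound 2, though the surroundings are not identical: in the first pair the site is para to a group of 6 heavy atoms, in the second para to a group of 8 heavy atoms. Because the first core showed an 11-fold higher number from compound 1 to compound 2 (1.04 log units; beyond the scatter), a step of comparable size is expected on the second core, so the expected step is an 11-fold higher number from compound 3 to compound 4 (1.03 log units; beyond the scatter). In this assay compound 4 is therefore estimated at 45000 nM, most likely between 12000 nM and 170000 nM.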

Compound 4, concentration for 50% growth inhibition: 4900 nM
The estimate for compound 4 lay 9.2-fold (0.96 log units) above the measured number; the whole stated range lies above it.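

On the second core, the methyl-for-iodo swap gave a 1.2-fold higher number from compound 3 to compound 4 (0.07 log units; within the scatter) in this assay, so the two compounds cannot be told apart on this read-out, whereas the same swap on the first core gave a clear change. The size of the step therefore did not carry from the core of compound 1 to the core of compound 3: the same change on two cores in this assay, an 11-fold higher number (1.04 log units; beyond the scatter) from compound 1 to compound 2 and a 1.2-fold higher number (0.07 log units; within the scatter) from compound 3 to compound 4, 9.4-fold (0.97 log units) apart, beyond the scatter of two such steps. Within the data shown here, this shows that, in this series, the step seen on one core cannot be taken as a guide to the other, but with only two matched pairs in a single assay it neither explains the difference nor gives a rule for any further core.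

The compounds shown leave open how a bromo group or an amine on the same aromatic carbon would behave on either core, and so whether the second core is insensitive to that position generally or only to this particular swap. They also leave open whether the gap between the two steps would hold in other cell lines.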